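Tetrahydroisoquinoline amide follows three compounds at the cytotoxicity limit

The source may report more compounds than this note shows. Statements on the series, on what has been measured and on what is new or still open speak of the compounds shown alone.

The shared core of compound 3 `CC(C)N(C(=O)C1CCN(C(=O)c2ccc(S(C)(=O)=O)c([N+](=O)[O-])c2)CC1)C(C)C` carries a diisopropylamino amide. In an ADME assay on HepG2 cells (Homo sapiens) for cytotoxicity, read by CellTiter-Glo and ATP content, with a stated time of 72 h (on this read-out lower numbers stand for an effect already at smaller amounts and higher numbers for an effect only at larger amounts of compound), compound 3 gives only a limit, > 27000 nM. Compound 1 `CS(=O)(=O)c1ccc(C(=O)N2CCC(C(=O)N3CCc4ccccc43)CC2)cc1[N+](=O)[O-]`, with a 2,3-dihydro-1H-indol-1-yl amide, likewise gives only a limit, > 27000 nM. Compound 2 `CN(Cc1ccccc1F)C(=O)C1CCN(C(=O)c2ccc(S(C)(=O)=O)c([N+](=O)[O-])c2)CC1`, with a (2-fluorobenzyl)(methyl)amino amide, also gives only a limit, > 27000 nM. The steps between them, a step that the two limits leave unreadable from compound 1 to compound 2, a step that the two limits leave unreadable from compound 1 to compound 3 and a step that the two limits leave unreadable from compound 2 to compound 3, are therefore not readable, because all three values sit at the limit of > 27000 nM in this assay, at which 3 of the 3 values shown sit.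

Compound 4 `CS(=O)(=O)c1ccc(C(=O)N2CCC(C(=O)N3CCc4ccccc4C3)CC2)cc1[N+](=O)[O-]` differs from compound 3 by 1,2,3,4-tetrahydroisoquinolin-2-yl in place of diisopropylamino on a carbonyl carbon. Going by these compounds, the measured steps that bear on this amide position all run between limits, so their size is unknown; they show only that three different amide substituents, including two ring-bearing ones, stayed at the limit. Compound 4 is therefore expected to show a step of a number no higher from compound 3 to compound 4 (the limit leaves the size open), none beyond the scatter, and to remain at the limit. For compound 4 the estimate in this assay is 27000 nM, with a range from 10000 nM to 100000 nM.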

Compound 4, half-maximal effective concentration: > 27000 nM
Compound 4 gave a limit, no number; the forecaster's own chance of this, stated with the estimate: 85%; the middle value sits exactly at the limit.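

Compound 4 gives only a limit in this assay, > 27000 nM. Its steps to compound 1, compound 2 and compound 3 cannot be read, because all four values sit together: the limit of > 27000 nM in this assay, at which 4 of the 4 values shown sit.

The compounds shown leave open at what concentration, if any, these four amides reach a half-maximal effect.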